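Compound 3: an expected cytotoxicity from two measured analogues

The compounds below may be only part of what the source reports. "The series", "measured", "known", "first", "only" and "open" are said of these compounds alone.

Compound 1, `O=C(COc1cccc2ccccc12)N/N=C/c1ccc(O)cc1`: 26.5 ug/mL
Compound 2, `C/C(=N\NC(=O)COc1cccc2ccccc12)c1ccc(C#N)cc1Br`: 12.1 ug/mL

In an ADME assay on MT4 cells (Homo sapiens) for cytotoxicity, read by MTT assay, with a stated time of 4 days (on this read-out higher numbers stand for lower toxicity in this test and lower numbers for higher toxicity in this test), compound 1 gives 26.5 ug/mL, the higher of the two numbers. Compound 2 gives 12.1 ug/mL, and the gap between the two compounds lies beyond the usual scatter, so compound 1 is the less toxic of the pair in this test.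

Compound 3, `O=C(COc1cccc2ccccc12)N/N=C/c1ccccc1Br`, differs from compound 1 in one place: 2-bromophenyl in place of 4-hydroxyphenyl on a carbon with a double bond to nitrogen. For the measured compounds named here, no measured pair shows this particular change, so its size cannot be read from the data. Compound 2 also carries a bromine and sits lower, but it differs from compound 1 in several places and is only a weak guide. In this assay the expected step is a 1.5-fold lower number from compound 1 to compound 3 (0.17 log units; within the scatter), a modest downward move that may not exceed the scatter. Compound 3 is therefore estimated at 18 ug/mL, within a range of 8 ug/mL to 40 ug/mL.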

Compound 3, half-maximal cytotoxic concentration: 11.4 ug/mL
The estimate for compound 3 lay 1.6-fold (0.20 log units) above the measured number; low and high end bracket the measured number.
By their numbers in this assay, from the lowest: compounds 3 and 2 (each within the scatter of the next); then compound 1.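

In this assay, 2-bromophenyl in place of 4-hydroxyphenyl on a carbon with a double bond to nitrogen gives a 2.3-fold lower number from compound 1 to compound 3 (0.37 log units; beyond the scatter), so this single change moves the read-out towards higher toxicity in this test. The group that leaves has a hydrogen-bond donor and acceptor and the group that enters has neither, but it also brings a bromine, and one step cannot separate these differences. Nothing available explains why the number falls.

On these data alone, what a plain phenyl, or a phenyl ring carrying an amine or a carboxylic acid, would give at this place remains open. So does whether the step comes from losing the group on compound 1 or from gaining the one on compound 3.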